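The compounds below may be only part of what the source reports. "The series", "measured", "known", "first", "only" and "open" are said of these compounds alone.

Compounds measured in a functional assay on A549 cells (Homo sapiens) for cytotoxicity, read by MTT assay; a higher number here means a weaker inhibitor, a lower number a stronger inhibitor:
compound 1 `N#Cc1c(Cl)c(Cl)c2nc(N)nc(N)c2c1Cl`, 29.7 ug/mL
compound 2 `N#Cc1c(NCc2ccccc2)c(Cl)c2nc(N)nc(N)c2c1F`, 34.1 ug/mL
compound 3 `N#Cc1c(NCc2ccccc2)c(F)c2nc(N)nc(N)c2c1F`, > 1000 ug/mL

Compound 3 stands at a limit of this assay, (the limit of > 1000 ug/mL in this assay, at which 1 of the 3 values shown sits), so no number is known for it. Among the compounds with values here, the only single-point step seen is an at least 29-fold higher number from compound 2 to compound 3 (1.46 log units; beyond the scatter), with fluoro replacing chloro. Compound 1 and compound 2 differ in two places and their values sit within the scatter of each other.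

Compound 4 `CCN(CC)c1c(C#N)c(F)c2c(N)nc(N)nc2c1F` differs from compound 3 by diethylamino in place of benzylamino on an aromatic carbon. Within the data shown here, no measured step covers an exchange of this amino group; compound 2 and compound 3 both carry benzylamino, compound 1 chloro. Compound 4 keeps the two fluoro groups. Compound 4 is therefore expected to sit near the limit, estimate 800 ug/mL (range 200 ug/mL to 2000 ug/mL), meaning an expected step of an at least 1.2-fold lower number from compound 3 to compound 4 (0.09 log units; that floor lies within the scatter).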

Compound 4, half-maximal inhibitory concentration: 26.5 ug/mL
Compound 4: middle estimate off by 30-fold (1.48 log units), on the high side; measured number below the stated range.
By their numbers in this assay, from the lowest: compounds 4, 1 and 2 (each within the scatter of the next). At a limit, above all of these: compound 3.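

In this assay, within the data shown here, diethylamino in place of benzylamino gives an at least 37-fold lower number from compound 3 to compound 4 (1.57 log units; beyond the scatter), the only measured change at this position, on an aromatic carbon ortho to a cyano group. That step is only a floor, since compound 3 stands at a limit of the assay: the limit of > 1000 ug/mL in this assay, at which 1 of the 4 values shown sits. Compound 4 keeps both fluoro groups, so these two groups alone do not hold a compound at the limit, and the result also depends on the amino group.

Open, going by these compounds, is how diethylamino behaves with the chloro group of compound 2 in place of fluoro. Also open, on these data alone, is how methylamino or morpholino would read at this position.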